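Alpha-ketooxazole series: iodo for methoxycarbonyl at compound 2

This account rests on a few compounds, and the source may have more. Where it says the series, first, only, none or still open, it means among the compounds named here.

Measured so far:
- compound 1, `CN(C)C(=O)c1cnc(C(=O)CCc2ccc(COc3ccccc3)cc2)o1`: 6.7 nM
- compound 2, `COC(=O)c1cnc(C(=O)CCc2ccc(Oc3ccccc3)cc2)o1`: 1.7 nM
- compound 3, `COC(=O)c1cccc(-c2cnc(C(=O)CCc3ccc(-c4ccc(CN5CCCCC5)cc4)cc3)o2)n1`: 9 nM

The three compounds share a core and differ in the side chain and in the group on the five-membered ring. In an assay for inhibition of Fatty-acid amide hydrolase 1 (Rattus norvegicus) (a higher number here means a weaker inhibitor, a lower number a stronger inhibitor), compound 2 gives 1.7 nM, the lowest of the three numbers. Compound 1 gives 6.7 nM and compound 3 gives 9 nM; both gaps from compound 2 lie beyond the scatter, so compound 2 is the strongest inhibitor among the measured three.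

Compound 4, `O=C(CCc1ccc(Oc2ccccc2)cc1)c1ncc(I)o1`, is not yet measured. It keeps the side chain of compound 2 and changes only the group on the five-membered ring: iodo in place of methoxycarbonyl on an aromatic carbon

Among the compounds with values here, no measured pair isolates this change, so its size is not known from the numbers. The methoxycarbonyl of compound 2 is replaced by a single atom without hydrogen-bond acceptors, and a modest loss is expected, so that the step of a 4.7-fold higher number from compound 2 to compound 4 (0.67 log units; beyond the scatter) is expected to run upward by somewhat more than the scatter. Compound 4 is therefore estimated at 8 nM, with a range from 2 nM to 30 nM.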

Compound 4, inhibition constant: 10 nM
The estimate for compound 4 lay 1.3-fold (0.10 log units) below the measured number, and the stated range covers the measured number.
By their numbers in this assay, from the lowest: compound 2; then compounds 1, 3 and 4 (each within the scatter of the next).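

In this assay iodo in place of methoxycarbonyl on the aromatic carbon next to the ring oxygen gives a 5.9-fold higher number from compound 2 to compound 4 (0.77 log units; beyond the scatter) with the side chain held constant, a direct reading of this position that compounds 1, 2 and 3 could not give. A single iodine atom with no hydrogen-bond acceptors still leaves compound 4 at 10 nM in this series, so hydrogen-bond acceptors in this group are not required for inhibition at that level, although the methoxycarbonyl of compound 2 gives the lower number. No measurement bears on why the number rises with this change.

Going by these compounds, how other groups at this position compare remains open, for example a carboxylic acid, a nitrile or bromo. Also open, on these data alone, is whether the same change gives a step of similar size with the side chains of compound 1 and compound 3.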